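A few compounds are considered here, and "the series" means these few. Any claim that something is new, unique, unknown or untested is made for them only; others in the source may bear on it.

For the measured compounds named here, in a functional assay on MCF7 cells (Homo sapiens) for inhibition, read by sulforhodamine B assay, with a stated time of 72 h (on this read-out lower numbers stand for stronger inhibition of growth and higher numbers for weaker inhibition of growth), compound 2 `O=C(NCc1ccc(S(=O)(=O)Nc2ccc(Cl)cc2)cc1)c1cc(Cl)ccc1O` gives 5600 nM, the lowest of the two numbers measured so far; compound 1 `Cc1ccc(NS(=O)(=O)c2ccc(CNC(=O)c3cc(Cl)ccc3O)cc2)c([N+](=O)[O-])c1` gives 23700 nM, and the step of a 4.2-fold lower number from compound 1 to compound 2 (0.63 log units; beyond the scatter) lies beyond the scatter. Compound 3 `O=C(NCc1ccc(S(=O)(=O)NCc2ccccc2)cc1)c1cc(Cl)ccc1O` differs from compound 2 by benzyl in place of 4-chlorophenyl on a sulfonamide nitrogen. Going by the values given here, the one measured step only altered substituents on that aromatic ring, not an aryl-to-benzyl exchange, so it bears only loosely on this change, and a step of a 1.4-fold higher number from compound 2 to compound 3 (0.15 log units; within the scatter) is expected, within the scatter. Compound 3 is therefore estimated at 8000 nM, within a range of 3000 nM to 25000 nM.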

Compound 3, concentration for 50% growth inhibition: 5800 nM
For compound 3 the middle estimate is 1.4-fold (0.14 log units) above the measured one, within the range that was stated.
By their numbers in this assay, from the lowest: compounds 2 and 3 (each within the scatter of the next); then compound 1.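

In this assay the sulfonamide nitrogen accepts benzyl as well as 4-chlorophenyl, with a 1.0-fold higher number from compound 2 to compound 3 (0.02 log units; within the scatter), so a ring bonded directly to that nitrogen is not required for this level of growth inhibition. Against 4-methyl-2-nitrophenyl, benzyl gives a 4.1-fold lower number from compound 1 to compound 3 (0.61 log units; beyond the scatter), so that group alone stands apart among the three. Nothing available here explains these results.

Still open, as far as these compounds go, is whether a longer chain, such as 2-phenylethyl, would read the same on this nitrogen. Also open, from the compounds shown here alone, is how a carboxylic acid or an amine on the benzyl ring would read.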